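This account rests on a few compounds, and the source may have more. Where it says the series, first, only, none or still open, it means among the compounds named here.

Working notes on the series. Three members of the shared core have been measured in a functional assay on A549 cells (Homo sapiens) for inhibition, read by MTT assay, with a stated time of 72 h; on this read-out lower numbers stand for stronger inhibition and higher numbers for weaker inhibition. Compound 1 `Cc1ccc(-c2cc(C(=O)N3CCC4(CC3)CC(=O)c3nn(C(C)(C)C)cc3O4)c3ccccc3n2)cc1` gives 5300 nM; compound 2 `Cc1ccccc1-c1cc(C(=O)N2CCC3(CC2)CC(=O)c2nn(C(C)(C)C)cc2O3)c2ccccc2n1` gives 1880 nM; compound 3 `CC(C)(C)n1cc2c(n1)C(=O)CC1(CCN(C(=O)c3cc(-c4ccc(Cl)cc4)nc4ccccc34)CC1)O2` gives 2330 nM. Compound 2 carries the lowest of the three numbers, though the gap to compound 3 is inside the scatter (a 1.2-fold higher number from compound 2 to compound 3 (0.09 log units; within the scatter)), so the two cannot be ordered; compound 1 is the only one set clearly apart, through a 2.8-fold lower number from compound 1 to compound 2 (0.45 log units; beyond the scatter) and a 2.3-fold lower number from compound 1 to compound 3 (0.36 log units; beyond the scatter).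

Compound 4 `CN1CCN(c2cc(C(=O)N3CCC4(CC3)CC(=O)c3nn(C(C)(C)C)cc3O4)c3ccccc3n2)CC1` is the next member. Relative to compound 2 the change is 4-methylpiperazin-1-yl in place of 2-methylphenyl on an aromatic carbon. Among the compounds with values here, every measured step so far has kept the six-membered aromatic ring of carbon only in place and moved or swapped a single substituent on it, and those steps were modest at most. Within the data shown here, no measured step replaces that ring with a non-aromatic ring carrying two nitrogen atoms, so no direction can be read from the data for this change, and the expectation has to be wide. On the balance of what the three compounds show, compound 4 is expected to give 4500 nM in this assay, with a range from 900 nM to 25000 nM. The expected step from compound 2 is a 2.4-fold higher number from compound 2 to compound 4 (0.38 log units; beyond the scatter), a guess rather than an extrapolation.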

Compound 4, half-maximal inhibitory concentration: > 10000 nM
Compound 4 was reported as a limit; the forecaster's own chance of this, stated with the estimate: 15%; middle value at least 2.2-fold (0.34 log units) from the limit.
By their numbers in this assay, from the lowest: compounds 2 and 3 (each within the scatter of the next); then compound 1. At a limit, above all of these: compound 4.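

In this assay compound 4 is reported only as a limit and not as a number: the limit of > 10000 nM in this assay, at which 1 of the 4 values shown sits. Within the data shown here, at this position, on the aromatic carbon next to the ring nitrogen, the earlier compounds exchanged one substituted phenyl group for another, whereas 4-methylpiperazin-1-yl brings a non-aromatic ring and gives the first clear move away from the two lowest numbers: an at least 5.3-fold higher number from compound 2 to compound 4 (0.72 log units; beyond the scatter) and an at least 4.2-fold higher number from compound 3 to compound 4 (0.63 log units; beyond the scatter). On these data alone, the remaining step, an at least 1.8-fold higher number from compound 1 to compound 4 (0.27 log units; that floor lies within the scatter), cannot be read as a separation, and all three steps are floors whose full size stays unknown.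

As far as these compounds go, it remains open whether the shift follows the loss of the aromatic ring, the entry of the two ring nitrogens or the methyl on the piperazine, and a piperidin-1-yl, morpholin-4-yl or unsubstituted piperazin-1-yl group at this position would begin to separate these. Also open, from the compounds shown here alone, is whether a phenyl ring carrying an amine or a carboxylic acid would stay with compound 2 and compound 3 or move towards compound 4.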